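The compounds below may be only part of what the source reports. "The series", "measured", "known", "first", "only" and "open" are said of these compounds alone.

Values measured in an ADME assay on microsomes from liver (Rattus norvegicus) for metabolic stability; on this read-out lower numbers stand for a shorter-lived compound and higher numbers for a longer-lived compound:

- Compound 1 `CCn1ncc2c(F)cc(-c3ccc(C(CC)(CC)c4nncn4C)c(=O)[nH]3)cc21` gives > 3 h
- Compound 2 `CC(C)C(c1ccc(-c2ccc3cccc(F)c3c2)[nH]c1=O)N1CCCCC1=O` gives 0.102 h

The entry for compound 1 is a limit of the assay and not a number. Among the compounds with values here, compound 2 at 0.102 h therefore holds the only actual number so far. Compound 3 `CC(C)C(Cc1nnn[nH]1)c1ccc(-c2ccc3cccc(F)c3c2)[nH]c1=O` carries (1H-tetrazol-5-yl)methyl in place of 2-oxopiperidin-1-yl on a saturated chain carbon bound to an aromatic carbon and a saturated chain carbon. Within the data shown here, no measured step between closely related compounds is available to size this change, and the forecast is loose. In this assay the expected 5.9-fold higher number from compound 2 to compound 3 (0.77 log units; beyond the scatter) is a rise beyond the scatter. For compound 3 the estimate is 0.6 h, with an expected range from 0.15 h to 2.5 h.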

Compound 3, half-life: 2.08 h
Compound 3: the middle estimate sits 3.5-fold (0.54 log units) below what was measured; low and high end bracket the measured number.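

In this assay, the group on this saturated chain carbon turns out to matter: (1H-tetrazol-5-yl)methyl in place of 2-oxopiperidin-1-yl gives a 20-fold higher number from compound 2 to compound 3 (1.31 log units; beyond the scatter). Within the data shown here, this is the first measured step at this position, and it lies beyond the scatter. The step is read between two actual numbers, and the assay's ceiling does not cut it off, since only compound 1 stands as a limit: the limit of > 3 h in this assay, at which 1 of the 3 values shown sits.

The compounds shown leave open whether the five-membered tetrazole ring or its methyl link carries the step. A carboxylic acid or an open-chain amide on this carbon would help to separate the two.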